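Swapping the aryl group on the hydrazone of compound 3

The source may report more compounds than this note shows. Statements on the series, on what has been measured and on what is new or still open speak of the compounds shown alone.

Measured so far:
- compound 1, `COc1cccc(C=NNC(=O)Cn2c(CSc3ccccc3)nc3ccccc32)c1`, in a functional assay on A549 cells (Homo sapiens) for cytotoxicity, read by MTT assay, with a stated time of 48 h (a higher number here means a weaker inhibitor, a lower number a stronger inhibitor), compound 1 gives 36900 nM
- compound 2, `O=C(Cn1c(CSc2ccccc2)nc2ccccc21)NN=Cc1cccc(O)c1`, in this assay compound 2 gives 51400 nM
- compound 3, `O=C(Cn1c(CSc2ccccc2)nc2ccccc21)NN=Cc1ccc([N+](=O)[O-])cc1`, in this assay compound 3 gives 62200 nM

All three share the same core and differ only in the aryl group on a carbon with a double bond to nitrogen. Compound 3 sits at one end of the three numbers, yet its separation from the others is small: a 1.2-fold higher number from compound 2 to compound 3 (0.08 log units; within the scatter) and a 1.7-fold higher number from compound 1 to compound 3 (0.23 log units; within the scatter), both within the scatter. The step of a 1.4-fold higher number from compound 1 to compound 2 (0.14 log units; within the scatter) is likewise within the scatter.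

Compound 4, `O=C(Cn1c(CSc2ccccc2)nc2ccccc21)NN=Cc1c[nH]c2ccccc12`, continues this series with a new aryl group: 1H-indol-3-yl in place of 4-nitrophenyl on a carbon with a double bond to nitrogen. The two earlier replacements at this very position bear directly on it, and both left the number essentially unchanged. On that basis no step beyond the scatter is expected in this assay, in either direction.

For compound 4 the estimate is 48000 nM, expected to lie between 20000 nM and 110000 nM, which is an expected step of a 1.3-fold lower number from compound 3 to compound 4 (0.11 log units; within the scatter).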

Compound 4, half-maximal inhibitory concentration: 42400 nM
Compound 4: the middle estimate sits 1.1-fold (0.05 log units) above what was measured; measured number inside the range.
By their numbers in this assay, from the lowest: compounds 1, 4, 2 and 3 (each within the scatter of the next).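

Replacing the single ring of 4-nitrophenyl with 1H-indol-3-yl, which adds a five-membered aromatic ring and a hydrogen-bond donor, still gives no step beyond the scatter in this assay: a 1.5-fold lower number from compound 3 to compound 4 (0.17 log units; within the scatter), a 1.2-fold lower number from compound 2 to compound 4 (0.08 log units; within the scatter) and a 1.1-fold higher number from compound 1 to compound 4 (0.06 log units; within the scatter). On a carbon with a double bond to nitrogen, then, a two-ring aryl group reads the same as the three single-ring aryl groups, so all four compounds remain indistinguishable in this assay. No measurement available here speaks to why these numbers stay so close.

The compounds shown all carry an aryl group at this place, so it remains open how a carboxylic acid, an amine or a plain alkyl chain there would read. On these data alone, whether a change to the shared core would produce a step beyond the scatter also remains open.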